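The source may hold more compounds than are shown below. What is called first, only, known or untested is meant among the compounds shown, and "the series" means these compounds.

In a functional assay on MCF7 cells (Homo sapiens) for cytotoxicity, read by sulforhodamine B assay, with a stated time of 24 h (on this read-out lower numbers stand for stronger inhibition and higher numbers for weaker inhibition), compound 3 (`CC(=O)N/N=C1\C(=O)Nc2ccc(S(=O)(=O)N3CCOCC3)cc21`) gives 56000 nM and shares the high end of the numbers with compound 2 (`Cc1ccc(/N=C2\C(=O)Nc3ccc(S(=O)(=O)N4CCOCC4)cc32)cc1`) at 55900 nM while compound 1 (`N=c1oc2ccccc2cc1C(=O)N/N=C1\C(=O)Nc2ccc(S(=O)(=O)N3CCOCC3)cc21`) sits lower with 20800 nM on that scale. Compound 4 (`O=C1Nc2ccc(S(=O)(=O)N3CCOCC3)cc2/C1=N/NS(=O)(=O)c1ccccc1`) differs from compound 3 in one place: phenylsulfonyl in place of acetyl on an amine nitrogen in short, phenylsulfonyl in place of acetyl on an amine nitrogen. Within the data shown here, two measured steps bear on this. The step of a 2.7-fold higher number from compound 1 to compound 3 (0.43 log units; beyond the scatter) removes a large ring-bearing group, so in this one pair the ring-bearing compound has the lower number. Compound 2 goes against that pattern, since the step of a 1.0-fold higher number from compound 2 to compound 3 (0.00 log units; within the scatter) stays within the scatter. In this assay a modest fall in the number is therefore expected, or none beyond the scatter. The estimated step is a 1.8-fold lower number from compound 3 to compound 4 (0.24 log units; within the scatter) for this swap. Compound 4 is expected at 32000 nM (estimated range 13000 nM to 70000 nM).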

Compound 4, half-maximal inhibitory concentration: 25300 nM
Compound 4: the middle estimate sits 1.3-fold (0.10 log units) above what was measured; measured number inside the range.
By their numbers in this assay, from the lowest: compounds 1 and 4 (each within the scatter of the next); then compounds 2 and 3 (each within the scatter of the next).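

In this assay, phenylsulfonyl in place of acetyl on the amine nitrogen gives a 2.2-fold lower number from compound 3 to compound 4 (0.35 log units; beyond the scatter), a modest step beyond the scatter. Swapping 4-methylphenyl for (phenylsulfonyl)amino on the double-bonded nitrogen gives a 2.2-fold lower number from compound 2 to compound 4 (0.34 log units; beyond the scatter), so an aromatic ring alone does not go with the lower number: compound 2 also carries one, yet stays within the scatter of compound 3. Nothing measured here explains these steps. As far as these compounds go, whether the sulfonyl link, the ring or both matter remains open. A methylsulfonyl or benzoyl group on that nitrogen would separate them.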